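This account rests on a few compounds, and the source may have more. Where it says the series, first, only, none or still open, it means among the compounds named here.

In an assay on HEK293 cells with D(4) dopamine receptor (Homo sapiens) as the target, read by FLIPR (on this read-out lower numbers stand for an effect already at smaller amounts and higher numbers for an effect only at larger amounts of compound), compound 3 `Fc1ccccc1N1CCN(Cc2nc3ccccc3[nH]2)CC1` gives 14.7 nM, the highest of the three numbers, though compound 1 `N#Cc1ccccc1N1CCN(Cc2nc3ccccc3[nH]2)CC1` at 14.6 nM and compound 2 `N#Cc1cccnc1N1CCN(Cc2nc3ccccc3[nH]2)CC1` at 13.9 nM both lie within the scatter of it. Compound 4 `c1cnc(N2CCN(Cc3nc4ccccc4[nH]3)CC2)nc1` differs from compound 3 in one place: pyrimidin-2-yl in place of 2-fluorophenyl on an amine nitrogen in a ring. Going by the values given here, two measured steps bear on this change. Exchanging the all-carbon ring for the cyanopyridinyl ring gave a 1.1-fold lower number from compound 1 to compound 2 (0.02 log units; within the scatter), and exchanging cyano for fluoro gave a 1.0-fold higher number from compound 1 to compound 3 (0.00 log units; within the scatter). The change here removes the fluoro and adds two ring nitrogens at once, but neither earlier step moved the number. A step of similar size, a 1.4-fold higher number from compound 3 to compound 4 (0.13 log units; within the scatter), is expected. Compound 4 is therefore estimated at 20 nM in this assay, with a range from 7 nM to 60 nM.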

Compound 4, half-maximal effective concentration: 44.8 nM
Estimate against measurement, compound 4: 2.2-fold (0.35 log units) below; the range from low to high includes it.
By their numbers in this assay, from the lowest: compounds 2, 1 and 3 (each within the scatter of the next); then compound 4.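

Until now, swapping the ring group on this amine nitrogen had left the number in this assay unmoved, but pyrimidin-2-yl does move it, with a 3.0-fold higher number from compound 3 to compound 4 (0.48 log units; beyond the scatter), a 3.2-fold higher number from compound 2 to compound 4 (0.51 log units; beyond the scatter) and a 3.1-fold higher number from compound 1 to compound 4 (0.49 log units; beyond the scatter). These steps are modest, yet they show that this position does not accept every six-membered aromatic ring equally. Nothing shown gives a reason for the rise. Going by these compounds, whether it goes with the two ring nitrogens or with the loss of the fluoro or cyano group stays open. A plain phenyl or a pyridin-2-yl at this position would help separate the two.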